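The source may hold more compounds than are shown below. What is called first, only, known or untested is meant among the compounds shown, and "the series" means these compounds.

Working notes on the series. Compound 1 `COc1ccc2c(c1)/C(=N/NC(=S)N1CCN(c3ccccc3)CC1)C(=O)N2`, compound 2 `O=C1Nc2cccc(Cl)c2/C1=N/NC(=S)N1CCN(c2ccccc2)CC1` and compound 3 `Cc1ccc(N2CCN(C(=S)N/N=C3\C(=O)Nc4ccc(Cl)cc43)CC2)cc1` share one core and one amine-bearing ring. In a functional assay on A549 cells (Homo sapiens) for inhibition, read by MTT assay, with a stated time of 72 h (a higher number here means a weaker inhibitor, a lower number a stronger inhibitor), compound 1 gives 7520 nM, compound 2 gives 55900 nM and compound 3 gives 10100 nM. Compound 3 stands second highest of the three measured numbers; its value lies within the scatter of compound 1, while compound 2 sits clearly higher, beyond the scatter. Compound 4 `O=C1Nc2ccc(Cl)cc2/C1=N/NC(=S)N1CCN(c2ccccc2F)CC1` differs from compound 3 in a single place: 2-fluorophenyl in place of 4-methylphenyl on an amine nitrogen in a ring. Going by the values given here, no measured pair isolates this change, so in this assay no step beyond the scatter is expected in either direction. Compound 4 is estimated at 9000 nM, with a range from 3000 nM to 30000 nM, an expected step of a 1.1-fold lower number from compound 3 to compound 4 (0.05 log units; within the scatter).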

Compound 4, half-maximal inhibitory concentration: 10500 nM
Estimate against measurement, compound 4: 1.2-fold (0.07 log units) below, and the stated range covers the measured number.
By their numbers in this assay, from the lowest: compounds 1, 3 and 4 (each within the scatter of the next); then compound 2.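

In this assay, going by these compounds alone, 2-fluorophenyl in place of 4-methylphenyl on an amine nitrogen in a ring gives a 1.0-fold higher number from compound 3 to compound 4 (0.02 log units; within the scatter) and is the only measured pair that isolates this position. The two substituted phenyl groups therefore read alike here, with compound 3 and compound 4 within the scatter of each other. No measured evidence bears on this result. As far as these compounds go, what stays open is whether a benzyl group or a carboxylic acid chain on that ring nitrogen would give a step beyond the scatter. From the compounds shown here alone, whether 2-fluorophenyl reads the same on the core of compound 1 also stays open.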